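The source may hold more compounds than are shown below. What is called first, only, known or untested is meant among the compounds shown, and "the series" means these compounds.

Of the compounds shown here, three that share one core have so far been tested in a functional assay on the whole organism for inhibition, with Rattus norvegicus as the target, read by paw edema, with stated times of 30 min and 3 h, at a dose of 0.28 mmol/kg by the oral route; a higher number here means more inhibition at the dose given (going by the name of the read-out), a lower number less inhibition. Compound 1 `CCNC(=O)c1nc(-c2cc(OC)c(OC)c(OC)c2)n(-c2ccc(OC)cc2)n1` gives 101%, compound 2 `COc1ccc(NC(=O)c2nc(-c3cc(OC)c(OC)c(OC)c3)n(-c3ccc(OC)cc3)n2)cc1` gives 99%, and compound 3 `COc1ccc(-n2nc(C(=O)Nc3ccc(C)cc3)nc2-c2cc(OC)c(OC)c(OC)c2)cc1` gives 88%. On these numbers compound 2 stands second of the three: its nearest neighbour is compound 1, at a gap within the scatter, and its furthest is compound 3, which lies beyond the scatter below it.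

Compound 4 `COc1ccc(-n2nc(C(=O)Nc3cccc(F)c3)nc2-c2cc(OC)c(OC)c(OC)c2)cc1` has not yet been measured. It differs from compound 2 in one place: 3-fluorophenyl in place of 4-methoxyphenyl on an amide-type nitrogen.

For the measured compounds named here, two measured steps bear on this change. The step of a number 11 percentage points lower from compound 2 to compound 3 (beyond the scatter) shows that exchanging the methoxy on the ring attached to the amide-type nitrogen for methyl cost a modest amount beyond the scatter. Likewise the step of a number 13 percentage points lower from compound 1 to compound 3 (beyond the scatter) shows a 4-methylphenyl on that nitrogen doing modestly worse than ethyl, whereas the step of a number 2 percentage points lower from compound 1 to compound 2 (within the scatter) shows a 4-methoxyphenyl staying within the scatter of ethyl. Compound 4 also gives up the methoxy on that ring, so a modest drop is expected, estimated as a number 10 percentage points lower from compound 2 to compound 4 (within the scatter). Compound 4 is therefore expected to give about 89%, in a range from 78% to 99%.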

Compound 4, a percentage reported as inhibition, in the whole organism at one dose (the size of the read-out at that dose, not a potency): 106%
Beside the measured number, compound 4's estimate is 17 percentage points below it; the measured number lies above the stated range.
By their numbers in this assay, from the lowest: compound 3; then compounds 2, 1 and 4 (each within the scatter of the next).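

In this assay, giving up the methoxy on the ring attached to the amide-type nitrogen does not by itself lower the number: 3-fluorophenyl in place of 4-methoxyphenyl gives a number 7 percentage points higher from compound 2 to compound 4 (within the scatter), so the earlier drop with 4-methylphenyl cannot be read as a general price for losing that methoxy. The two rings without a methoxy also part ways, with a number 18 percentage points higher from compound 3 to compound 4 (beyond the scatter), while the change from ethyl to 3-fluorophenyl gives a number 5 percentage points higher from compound 1 to compound 4 (within the scatter); among these four groups on that nitrogen, only the 4-methylphenyl of compound 3 stands apart from the others. No measurement shown here accounts for why 3-fluorophenyl and 4-methylphenyl differ.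

Compound 4 changes both the group on the ring and where it sits, so 4-fluorophenyl and 3-methoxyphenyl would be needed to tell those two changes apart. On these data alone, whether a longer chain such as butyl, or a phenyl ring carrying a carboxylic acid, would hold up on that nitrogen also remains open, and a reading at a single dose gives the size of the inhibition at that dose, not a potency.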